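Fluoro added to the aryl ring of compound 1

The compounds below may be only part of what the source reports. "The series", "measured", "known", "first", "only" and "open" are said of these compounds alone.

Measured so far:
compound 1, `COc1cc(N(CC2CC2)c2cccc(C(F)(F)F)c2)cnc1C(=O)[C@H]1C[C@@H]1C(=O)O`: 6.42 nM
compound 2, `CCCN(c1cccc(C(F)(F)F)c1)c1cnc(C(=O)[C@H]2C[C@@H]2C(=O)O)c(OC)c1`: 7.9 nM

In an assay for inhibition of leukotriene C4 synthase (Homo sapiens), read by LC-MS, with stated times of 15 min and 30 min (on this read-out higher numbers stand for weaker inhibition and lower numbers for stronger inhibition), compound 1 holds the lowest of the two numbers shown, though a 1.2-fold higher number from compound 1 to compound 2 (0.09 log units; within the scatter) stays within the scatter, so compound 1 and compound 2 cannot be ranked against each other. Compound 3, `COc1cc(N(CC2CC2)c2cc(C(F)(F)F)ccc2F)cnc1C(=O)[C@H]1C[C@@H]1C(=O)O`, differs from compound 1 by fluoro in place of hydrogen on an aromatic carbon, set ortho to a large group and para to the trifluoromethyl group. Among the compounds with values here, no measured step touches this ring, and the only step seen, from compound 1 to compound 2, was small. The expectation for compound 3 is therefore a 1.0-fold higher number from compound 1 to compound 3 (0.01 log units; within the scatter), giving an estimated 6.5 nM with a range from 2.5 nM to 17 nM.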

Compound 3, half-maximal inhibitory concentration: 2.08 nM
The estimate for compound 3 lay 3.1-fold (0.49 log units) above the measured number; measured number outside the range, below it.
By their numbers in this assay, from the lowest: compound 3; then compounds 1 and 2 (each within the scatter of the next).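

In this assay fluoro in place of hydrogen on this aromatic carbon, ortho to a large group and para to a trifluoromethyl group, gives a 3.1-fold lower number from compound 1 to compound 3 (0.49 log units; beyond the scatter) and so shows that this position responds to a single added atom. The earlier pair differed only in the chain on the nitrogen and showed no step beyond the scatter. Nothing available here accounts for the size of this step.
From the compounds shown here alone, whether chloro or methyl on the same carbon would give a similar step remains open. So does whether fluoro would lower the number on compound 2 as well.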